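This account rests on a few compounds, and the source may have more. Where it says the series, first, only, none or still open, it means among the compounds named here.

Measured so far in an ADME assay on HOS cells (Homo sapiens) for cytotoxicity; on this read-out lower numbers stand for higher toxicity in this test and higher numbers for lower toxicity in this test:
compound 1 `CN1CCN(c2cccn3cc(CN(C)[C@H]4CCCc5cccnc54)nc23)CC1` gives > 5000 nM
compound 2 `CCN1CCN(c2cccc3nc(CN(C)[C@H]4CCCc5cccnc54)cn23)CC1` gives 3900 nM
compound 3 `CN1CCN(c2cccc3nc(CN(C)[C@H]4CCCc5cccnc54)[nH]c23)CC1` gives > 5000 nM

The reading for compound 1 is a limit of the assay, not a number. The reading for compound 3 is likewise a limit; see (the limit of > 5000 nM in this assay, at which 2 of the 3 values shown sit). Going by the values given here, compound 2 therefore carries the only actual number in this assay, the other two readings sit at the limit.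

Compound 4 `CC(C)N1CCN(c2cccc3nc(CN(C)[C@H]4CCCc5cccnc54)cn23)CC1` has not been measured in this assay. Relative to compound 2 it differs by methyl in place of hydrogen on a saturated chain carbon bound to an amine nitrogen in a ring and a saturated chain carbon. Among the compounds with values here, no step between measured compounds isolates this change, so nothing here shows what it does. The expectation is no step beyond the scatter: a 1.1-fold higher number from compound 2 to compound 4 (0.04 log units; within the scatter). Compound 4 is accordingly expected to give about 4300 nM, within 2000 nM to 9000 nM, with a fair chance that only a limit is reported.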

Compound 4, half-maximal cytotoxic concentration: 7100 nM
Compound 4: middle estimate off by 1.7-fold (0.22 log units), on the low side; the range from low to high includes it.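

In this assay, going by these compounds alone, the change from 4-ethylpiperazin-1-yl to 4-isopropylpiperazin-1-yl gives a 1.8-fold higher number from compound 2 to compound 4 (0.26 log units; within the scatter), the first step that isolates a single change. Added methyl on this saturated chain carbon therefore does not move the read-out beyond the scatter, and compound 4 gives a number, not a limit. The remaining two readings in the series are limits: the limit of > 5000 nM in this assay, at which 2 of the 4 values shown sit.

As far as these compounds go, whether a longer chain, a cyclopropyl group or a hydroxyethyl group on this piperazine nitrogen would give a step beyond the scatter remains open. So does the effect of a plain hydrogen there.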